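A trifluoromethyl step from a compound at the limit

A few compounds are considered here, and "the series" means these few. Any claim that something is new, unique, unknown or untested is made for them only; others in the source may bear on it.

Compound 1 `CSc1cccc(N2C(=O)CN(c3ccccc3)CC2(C)C(=O)NC2CCCC2)c1`: > 50000 nM, a limit
Compound 2 `CSc1cccc(N2C(=O)CN(c3ccccc3)CC2C(=O)NC2CCCC2)c1`: > 50000 nM, a limit

In an ADME assay on HepG2 cells (Homo sapiens) for cytotoxicity (a lower number here means that less compound is tolerated, a higher number that more compound is tolerated), compound 2 gives > 50000 nM, which is a limit. Compound 3 `CSc1cccc(N2C(=O)CN(c3ccc(C(F)(F)F)cc3)CC2C(=O)NC2CCCC2)c1` differs from it by trifluoromethyl in place of hydrogen on an aromatic carbon. Within the data shown here, only one measured step exists, a step that the two limits leave unreadable from compound 1 to compound 2, and it concerns a different change. Among the measured compounds shown here, the only evidence is the limit of > 50000 nM in this assay, at which 2 of the 2 values shown sit, which gives no size for this change, so no step beyond the scatter is expected in this assay. The estimated step is a number no higher from compound 2 to compound 3 (the limit leaves the size open). Compound 3 is expected at 50000 nM, within an estimated range of 20000 nM to 100000 nM.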

Compound 3, half-maximal cytotoxic concentration: 10000 nM
For compound 3 the middle estimate is 5.0-fold (0.70 log units) above the measured one; the measured number lies below the stated range.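

Trifluoromethyl in place of hydrogen, on an aromatic carbon para to a large group, gives the first readable change in this assay, with an at least 5.0-fold lower number from compound 2 to compound 3 (0.69 log units; beyond the scatter) as its size. The earlier step cannot be read, as both of its values are limits. This position on the phenyl ring is therefore one where a substituent lowers the tolerated concentration of the compound.

On these data alone, whether a smaller group such as chlorine or methoxy at this place gives a similar step remains open. So does whether trifluoromethyl lowers the number equally on compound 1, which carries the extra methyl.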